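Pyridinyl in place of dimethoxyphenyl on an inactive series

A few compounds are considered here, and "the series" means these few. Any claim that something is new, unique, unknown or untested is made for them only; others in the source may bear on it.

Compound 1 `COc1cccc(Cc2cc(-c3cccs3)nn(CC(=O)Nc3ccc(F)cc3)c2=O)c1` in an assay on HL-60 cells for agonist activity at N-formyl peptide receptor 3 (Homo sapiens), read by calcium flux (on this read-out lower numbers stand for an effect already at smaller amounts and higher numbers for an effect only at larger amounts of compound), gives a limit of the assay, > 50000 nM.
Compound 2 `COc1ccc(-c2cc(Cc3cccc(OC)c3)c(=O)n(CC(=O)Nc3ccc(F)cc3)n2)cc1` in this assay gives a limit of the assay, > 50000 nM.
Compound 3 `COc1cc(Cc2cc(C)nn(CC(=O)Nc3ccc(Br)cc3)c2=O)cc(OC)c1` in this assay gives a limit of the assay, > 50000 nM.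

Compound 3 therefore stands at the limit, together with the other two measured compounds; none of the three gives a number, so no order among them can be read. Within the data shown here, the only measured step that differs in one place, a step that the two limits leave unreadable from compound 1 to compound 2, is left unreadable by the two limits and carries no size. Its relation to the present change is also loose, since it alters a different part of the shared core.

Compound 4 `Cc1cc(Cc2cccnc2)c(=O)n(CC(=O)Nc2ccc(Br)cc2)n1` differs from compound 3 by pyridin-3-yl in place of 3,5-dimethoxyphenyl on a saturated chain carbon bound to an aromatic carbon. Among the measured compounds shown here, no measured step bears directly on this change, and the only evidence to weigh is the limit of > 50000 nM in this assay, at which 3 of the 3 values shown sit. With everything measured sitting at the limit, compound 4 is expected to stay there as well, with the step of a number no higher from compound 3 to compound 4 (the limit leaves the size open) reflecting no readable movement. The estimate for compound 4 in this assay is 50000 nM, with a range from 10000 nM to 200000 nM.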

Compound 4, half-maximal effective concentration: > 50000 nM
Compound 4: a limit, no number; the forecaster's own chance of this, stated with the estimate: 85%; the middle value lies on the limit itself.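

Compound 3 and compound 4 both give only a limit in this assay and no number, so the step between them cannot be read. The compounds shown leave open how they would rank and which change to the shared core would give a measurable value, as all share one result: the limit of > 50000 nM in this assay, at which 4 of the 4 values shown sit.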